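Shifting the trifluoromethyl group: compound 3 to compound 4

The source may report more compounds than this note shows. Statements on the series, on what has been measured and on what is new or still open speak of the compounds shown alone.

- compound 1 `CN(C)CCCNc1nc2cc([N+](=O)[O-])ccc2nc1NCc1ccc(Cl)cc1` in an ADME assay on HEK293 cells (Homo sapiens) for cytotoxicity, read by MTT assay, with a stated time of 24 h (a lower number here means a stronger inhibitor, a higher number a weaker inhibitor), gives 10.7 ug/mL
- compound 2 `Cc1ccc(CNc2nc3ccc([N+](=O)[O-])cc3nc2NCCCN(C)C)cc1` gives 15.8 ug/mL
- compound 3 `CN(C)CCCNc1nc2cc([N+](=O)[O-])ccc2nc1NCc1ccccc1C(F)(F)F` gives 24.7 ug/mL

In this assay, for the measured compounds named here, compound 3 stands clear of only one measured neighbour, with a 2.3-fold higher number from compound 1 to compound 3 (0.36 log units; beyond the scatter) as the modest gap. Its number cannot be separated from the other neighbour, with a 1.6-fold higher number from compound 2 to compound 3 (0.19 log units; within the scatter) inside the scatter.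

Compound 4 `CN(C)CCCNc1nc2cc([N+](=O)[O-])ccc2nc1NCc1cccc(C(F)(F)F)c1` has 3-(trifluoromethyl)phenyl in place of 2-(trifluoromethyl)phenyl on a saturated chain carbon bound to a nitrogen on an aromatic ring. Going by the values given here, no measured step isolates this kind of change. The nearest guides are the two steps above, which exchange the whole aromatic group and stay small. A small shift toward the other members is therefore expected, given compound 1 at 10.7 ug/mL and compound 2 at 15.8 ug/mL, but nothing beyond the scatter. The expected change is a 1.4-fold lower number from compound 3 to compound 4 (0.14 log units; within the scatter) in this estimate.

For compound 4 the estimated value is 18 ug/mL, with an expected range from 9 ug/mL to 36 ug/mL.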

Compound 4, half-maximal inhibitory concentration: 7.99 ug/mL
For compound 4 the middle estimate is 2.3-fold (0.35 log units) above the measured one, outside the stated range (below it).
By their numbers in this assay, from the lowest: compounds 4, 1, 2 and 3 (each within the scatter of the next, the first and the last beyond it).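

For the compounds shown here, exchanging 2-(trifluoromethyl)phenyl for 3-(trifluoromethyl)phenyl, with the atoms unchanged, gives a 3.1-fold lower number from compound 3 to compound 4 (0.49 log units; beyond the scatter) in this assay and shows that the arrangement of this group alone can move the number beyond the scatter, which the earlier steps, each exchanging differently substituted aromatic groups, could not show. Compound 4 does not separate from the other two neighbours, with a 2.0-fold lower number from compound 2 to compound 4 (0.30 log units; within the scatter) and a 1.3-fold lower number from compound 1 to compound 4 (0.13 log units; within the scatter) both inside the scatter, so the 2-(trifluoromethyl)phenyl of compound 3 is the member set apart by this step. No measurement here accounts for the shift.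

On these data alone, it remains open where 4-(trifluoromethyl)phenyl would fall at this place on the saturated chain carbon. As far as these compounds go, whether the same shift holds for chloro or methyl on the phenyl ring also remains open.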